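The source may report more compounds than this note shows. Statements on the series, on what has been measured and on what is new or still open speak of the compounds shown alone.

Series notes. Compound 1 `O=C(Nc1cc(-c2ccccc2)nn1-c1ccccc1)c1cccc(Cl)c1` in an assay on isolated protein with metabotropic glutamate receptor 5 (Rattus norvegicus) as the target (on this read-out higher numbers stand for an effect only at larger amounts of compound and lower numbers for an effect already at smaller amounts), gives 200 nM. For compound 2 `O=C(Nc1cc(-c2ccccc2)nn1-c1ccccc1)c1ccccc1O` the same this assay reports only a limit, > 10000 nM, so compound 2 stands at the limit of > 10000 nM in this assay, at which 1 of the 2 values shown sits. Going by the values given here, the single measured step, an at least 50-fold higher number from compound 1 to compound 2 (1.69 log units; beyond the scatter), runs toward that limit. Compound 3 `O=C(Nc1cc(-c2ccccc2)nn1-c1ccccc1)c1ccc(Cl)cc1` differs from compound 2 by 4-chlorophenyl in place of 2-hydroxyphenyl on a carbonyl carbon. This largely reverses the measured step, with the chlorine now carried as 4-chlorophenyl instead of 3-chlorophenyl. In this assay compound 3 is therefore expected to show an at least 25-fold lower number from compound 2 to compound 3 (1.39 log units; beyond the scatter), a large fall in the number. The estimate for compound 3 is 400 nM, with a range of 100 nM to 5000 nM.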

Compound 3, half-maximal effective concentration: 100 nM
Estimate against measurement, compound 3: 4.0-fold (0.60 log units) above, within the range that was stated.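

In this assay, 4-chlorophenyl in place of 3-chlorophenyl on a carbonyl carbon gives a 2.0-fold lower number from compound 1 to compound 3 (0.30 log units; within the scatter), so these two chlorophenyl groups cannot be told apart here. The large gap to 2-hydroxyphenyl is therefore not confined to one chlorophenyl group, with an at least 100-fold lower number from compound 2 to compound 3 (2.00 log units; beyond the scatter). Compound 2 is a limit, so this step is only a bound: the limit of > 10000 nM in this assay, at which 1 of the 3 values shown sits.

The hydroxyl and chlorine differ together with their ring positions, so the contribution of each remains unresolved. A plain phenyl or a 4-hydroxyphenyl on the carbonyl carbon would bear on that question.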